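The compounds below may be only part of what the source reports. "The series", "measured", "known", "first", "only" and "open" are said of these compounds alone.

Measured so far:
compound 1 `Brc1ccc(-c2cc(COc3ccccc3-c3nc4ccccc4s3)on2)cc1` — 20000 nM
compound 2 `Fc1ccccc1-c1cc(COc2ccccc2-c2nc3ccccc3s2)on1` — 23900 nM

Among the measured compounds shown here, compound 2 gives the higher of the two numbers in a functional assay on MCF7 cells (Homo sapiens) for cytotoxicity, read by MTT assay, with a stated time of 24 h (a lower number here means a stronger inhibitor, a higher number a weaker inhibitor), but the one measured step, a 1.2-fold higher number from compound 1 to compound 2 (0.08 log units; within the scatter), stays within the scatter, so the two measured compounds are not separated on this assay. Compound 3 `COc1ccc(-c2cc(COc3ccccc3-c3nc4ccccc4s3)on2)cc1` carries 4-methoxyphenyl in place of 2-fluorophenyl on an aromatic carbon. For the measured compounds named here, the only step that bears on it is the exchange of the aryl group at the same position, from compound 1 to compound 2, and that step is within the scatter; there is no measured pair that moves a substituent onto a 4-methoxyphenyl group. Nothing in the two numbers therefore supports an expected shift beyond the scatter in either direction for compound 3. The estimate for compound 3 in this assay is 20000 nM, with a range from 8000 nM to 50000 nM, which corresponds to an expected step of a 1.2-fold lower number from compound 2 to compound 3 (0.08 log units; within the scatter).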

Compound 3, half-maximal inhibitory concentration: 22100 nM
The estimate for compound 3 lay 1.1-fold (0.04 log units) below the measured number; measured number inside the range.
By their numbers in this assay, from the lowest: compounds 1, 3 and 2 (each within the scatter of the next).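

In this assay, 4-methoxyphenyl in place of 2-fluorophenyl gives a 1.1-fold lower number from compound 2 to compound 3 (0.03 log units; within the scatter), and methoxy in place of bromo gives a 1.1-fold higher number from compound 1 to compound 3 (0.04 log units; within the scatter), so all three aryl groups on this carbon of the five-membered ring remain unseparated. The entering 4-methoxyphenyl group brings a hydrogen-bond acceptor where the groups in compound 1 and compound 2 count none, yet this difference comes with no step beyond the scatter. No supporting measurement bears on why these numbers coincide.

The compounds shown leave open whether a phenyl group carrying an amine or a carboxylic acid, or a longer chain in place of the aryl group, would move the number beyond the scatter. They also leave open how changes elsewhere on the shared core would read in this assay.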